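A few compounds are considered here, and "the series" means these few. Any claim that something is new, unique, unknown or untested is made for them only; others in the source may bear on it.

Measured compounds in an assay on Huh-7 cells for agonist activity at Bile acid receptor (Homo sapiens), read by a luciferase reporter; a higher number here means that more compound is needed for the effect, a lower number that less compound is needed:

compound 1 `CCC(CC)n1c(-c2ccc(OCc3c(-c4c(Cl)cccc4Cl)noc3C(C)C)cc2)nc2ccc(C(=O)O)cc21` — 0.8 nM
compound 2 `CC(C)c1onc(-c2c(Cl)cccc2Cl)c1COc1ccc(-c2nc3ccc(C(=O)O)cc3n2-c2ccc(F)cc2)cc1` — 32.2 nM
compound 3 `CC(C)Cn1c(-c2ccc(OCc3c(-c4c(Cl)cccc4Cl)noc3C(C)C)cc2)nc2ccc(C(=O)O)cc21` — 5.26 nM

Compound 1 gives the lowest number of the three in this assay. The measured steps all change the group on the aromatic nitrogen of the shared core: a 40-fold higher number from compound 1 to compound 2 (1.60 log units; beyond the scatter) and a 6.6-fold higher number from compound 1 to compound 3 (0.82 log units; beyond the scatter), with the pair of compounds 2 and 3 showing a 6.1-fold lower number from compound 2 to compound 3 (0.79 log units; beyond the scatter). Both steps away from compound 1 raise the number beyond the scatter.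

Compound 4 `CCC(CC)n1c(-c2ccc(OCc3c(-c4c(Cl)cccc4Cl)noc3C(C)C)cc2Cl)nc2ccc(C(=O)O)cc21` differs from compound 1 elsewhere: chloro in place of hydrogen on an aromatic carbon. The pentan-3-yl on the aromatic nitrogen, the part that the measured steps vary, is kept. Within the data shown here, no measured pair changes a substituent on this six-membered ring, so none of the steps bears directly on the change; the only guidance is that compound 1 sits at the low end of the series and that a single chloro is a small addition. The expectation is therefore a step of about a 1.5-fold higher number from compound 1 to compound 4 (0.18 log units; within the scatter), not clearly beyond the scatter in either direction. Compound 4 is estimated at 1.2 nM, with a range of 0.3 nM to 5 nM.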

Compound 4, half-maximal effective concentration: 1.6 nM
For compound 4 the middle estimate is 1.3-fold (0.12 log units) below the measured one, within the range that was stated.
By their numbers in this assay, from the lowest: compounds 1 and 4 (each within the scatter of the next); then compound 3; then compound 2.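

In this assay, chloro in place of hydrogen on this aromatic carbon, ortho to a large group and meta to a large group, gives a 2.0-fold higher number from compound 1 to compound 4 (0.30 log units; within the scatter) and so leaves compound 1 and compound 4 indistinguishable. The earlier steps shown here all lay on the aromatic nitrogen and all went beyond the scatter, whereas this first look at the six-membered aromatic ring, with pentan-3-yl kept, does not. No measurement at hand speaks to a cause of this result.

On these data alone, whether fluoro, methyl, methoxy or nitrile on this carbon would read like chloro stays open, as does chloro on the other carbons of this ring. Also open, as far as these compounds go, is whether chloro would read the same with isobutyl or 4-fluorophenyl on the aromatic nitrogen in place of pentan-3-yl.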